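The compounds below may be only part of what the source reports. "The series", "measured", "known", "first", "only" and "open" are said of these compounds alone.

In a functional assay on QGY-7703 cells (Homo sapiens) for cytotoxicity, read by MTT assay, with a stated time of 24 h (a higher number here means a weaker inhibitor, a lower number a stronger inhibitor), compound 1 `CN1C/C(=C\c2cccnc2)C(=O)/C(=C/c2ccccc2F)C1` gives 4470 nM, compound 2 `Cc1ccc(S(=O)(=O)N2C/C(=C\c3cccnc3)C(=O)/C(=C/c3ccccc3F)C2)cc1` gives 9700 nM and compound 3 `O=C1/C(=C/c2cccnc2)CN(S(=O)(=O)c2ccc([N+](=O)[O-])cc2)C/C1=C\c1ccccc1F` gives 5600 nM. The value of compound 3 lies within the usual scatter of both other values, so it cannot be ranked against either of them.

The next compound, compound 4 `O=C1/C(=C/c2cccnc2)CN(S(=O)(=O)c2ccc(F)cc2)C/C1=C\c1ccccc1F`, has not yet been measured. It differs from compound 3 by one swap: fluoro in place of nitro on an aromatic carbon. In words, this is fluoro in place of nitro on an aromatic carbon, para to a large group.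

The other measured step, a 2.2-fold higher number from compound 1 to compound 2 (0.34 log units; beyond the scatter), is a modest one, but it replaced methyl on an amine nitrogen in a ring and so concerns a different part of the molecule. The closest guide is a 1.7-fold lower number from compound 2 to compound 3 (0.24 log units; within the scatter), where nitro replaced methyl on the same aromatic carbon, so no step beyond the scatter is expected in this assay here, and no direction can be named.

The estimated step is a 1.1-fold higher number from compound 3 to compound 4 (0.03 log units; within the scatter), which is expected to stay within the scatter. For compound 4 the expected value is 6000 nM, with an estimated range of 2800 nM to 13000 nM.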

Compound 4, half-maximal inhibitory concentration: 15300 nM
Compound 4: middle estimate off by 2.6-fold (0.41 log units), on the low side; measured number outside the range, above it.
By their numbers in this assay, from the lowest: compounds 1, 3, 2 and 4 (each within the scatter of the next, the first and the last beyond it).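

Among these compounds, replacing nitro with fluoro on this aromatic carbon gives a 2.7-fold higher number from compound 3 to compound 4 (0.44 log units; beyond the scatter) in this assay, the first step at this position that lies beyond the scatter, so the group held here can matter. Methyl and fluoro cannot be told apart at this carbon, with a 1.6-fold higher number from compound 2 to compound 4 (0.20 log units; within the scatter), so a clear separation appears only between nitro and fluoro, in a series of just three groups. Swapping the methyl on the ring nitrogen for (4-fluorophenyl)sulfonyl gives a 3.4-fold higher number from compound 1 to compound 4 (0.53 log units; beyond the scatter), a modest change across the whole sulfonyl replacement.

Nothing measured here explains why nitro and fluoro differ. The compounds shown also leave open how an amine or a methoxy group on this same aromatic carbon would compare.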